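This account rests on a few compounds, and the source may have more. Where it says the series, first, only, none or still open, it means among the compounds named here.

Measured in an ADME assay on MT4 cells (Homo sapiens) for cytotoxicity, read by MTT assay, with a stated time of 5 days; on this read-out lower numbers stand for higher toxicity in this test and higher numbers for lower toxicity in this test:
compound 1 `N#Cc1ccc(Nc2cc(NS(=O)(=O)c3ccc(C#N)cc3)ccn2)cc1`: 93400 nM
compound 2 `CC(C)(C)c1ccc(S(=O)(=O)Nc2ccnc(Nc3ccc(C#N)cc3)c2)cc1`: 29300 nM
compound 3 `N#Cc1ccc(Nc2nccc(NS(=O)(=O)c3ccc(C#N)cc3)n2)cc1`: 159000 nM

Compound 4 `CC(C)(C)c1ccc(S(=O)(=O)Nc2ccnc(Nc3ccc(C#N)cc3)n2)cc1` remains to be measured in this assay. It differs from compound 3 by tert-butyl in place of cyano on an aromatic carbon. The same change separates compound 1 from compound 2, (tert-butyl in place of cyano on an aromatic carbon), and there it gave a 3.2-fold lower number from compound 1 to compound 2 (0.50 log units; beyond the scatter). The difference between the core of compound 1 and the core of compound 3 is not broken down here; compound 3 and compound 1 give numbers within the usual scatter of each other, while compound 2 stands lowest of the three. The change is seen in one measured pair only, so the expectation rests on that single step. Compound 4 is expected to show a 2.9-fold lower number from compound 3 to compound 4 (0.46 log units; beyond the scatter), taken from a 3.2-fold lower number from compound 1 to compound 2 (0.50 log units; beyond the scatter). Compound 4 is therefore estimated at 55000 nM in this assay, with a likely range from 25000 nM to 120000 nM.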

Compound 4, half-maximal cytotoxic concentration: 30300 nM
Compound 4: middle estimate off by 1.8-fold (0.26 log units), on the high side, and the stated range covers the measured number.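

In this assay, tert-butyl in place of cyano again gives a lower number, a 5.2-fold lower number from compound 3 to compound 4 (0.72 log units; beyond the scatter). The step carries across the two cores without a size difference that can be told apart: the same change on two cores in this assay, a 3.2-fold lower number (0.50 log units; beyond the scatter) from compound 1 to compound 2 and a 5.2-fold lower number (0.72 log units; beyond the scatter) from compound 3 to compound 4, 1.6-fold (0.22 log units) apart, within the scatter of two such steps

This rests on two pairs only, so it does not show that the step would hold on a further core, nor why the number falls.

Still open, as far as these compounds go, is whether another group on the same aromatic carbon, such as an amine, a carboxylic acid or a longer chain, would shift the number in the same way. Also open, from the compounds shown here alone, is whether the step would persist with the remaining nitrile replaced by an amine.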